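A Thiophen-2-yl Group Replaces Cyanomethyl

The source may report more compounds than this note shows. Statements on the series, on what has been measured and on what is new or still open speak of the compounds shown alone.

In an ADME assay on MDCK cells (Canis lupus familiaris) for cytotoxicity, read by MTT assay, with a stated time of 24 h (a higher number here means that more compound is tolerated, a lower number that less compound is tolerated), compound 1 (`N#CCCN(Cc1cccs1)S(=O)(=O)c1ccc(Br)cc1`) gives only a limit, > 173000 nM and no exact number. In this assay compound 2 (`N#CCCN(Cc1cccs1)S(=O)(=O)c1ccc(C#N)cc1`) likewise gives only a limit, > 201000 nM and no exact number.

Compound 3 (`O=S(=O)(c1ccc(Br)cc1)N(Cc1cccs1)Cc1cccs1`) has not been measured yet. Compared with compound 1, it carries thiophen-2-yl in place of cyanomethyl on a saturated chain carbon bound to a sulfonamide nitrogen. The same difference can also be read as 2-cyanoethyl giving way to (thiophen-2-yl)methyl.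

Within the data shown here, only one measured step bears on this change, and only loosely. It is a step that the two limits leave unreadable from compound 1 to compound 2 and it swaps bromo for cyano on an aromatic carbon, a different place from the one changing here. It offers no size to carry over. No step beyond the usual scatter is therefore expected in this assay and the data give no direction. This expectation leans on compound 1, whose > 173000 nM is a limit. The estimate amounts to an expected at least 1.1-fold lower number from compound 1 to compound 3 (0.06 log units; that floor lies within the scatter) and no more than that. For compound 3 the expected half-maximal cytotoxic concentration is about 150000 nM with an estimated range of 60000 nM to 170000 nM and the result may again be only a limit.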

Compound 3, half-maximal cytotoxic concentration: 81000 nM
The estimate for compound 3 lay 1.9-fold (0.27 log units) above the measured number, within the range that was stated.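

Changing the chain on the sulfonamide nitrogen does move the read-out: in this assay, thiophen-2-yl in place of cyanomethyl on a saturated chain carbon bound to a sulfonamide nitrogen gives an at least 2.1-fold lower number from compound 1 to compound 3 (0.32 log units; beyond the scatter), so less compound is tolerated. Compound 3 is the only compound shown with an exact number, 81000 nM, while the earlier swap of bromo for cyano on the aromatic carbon left no step that could be read. The real size of the new step may be larger than the printed floor, because compound 1 reached only a limit and not a number: the limit of > 173000 nM in this assay, at which 1 of the 3 values shown sits.

The compounds shown cannot separate the loss of the nitrile from the arrival of the five-membered aromatic ring as the source of this drop, and a simple (thiophen-2-yl)methyl swap is the only change tested at this place. Going by these compounds, how an amine, a carboxylic acid or a longer chain would fare there stays open, as does whether the same swap would give a similar step with cyano rather than bromo on the aromatic carbon.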